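From compound 2 to compound 3: a double bond leaves

The source may report more compounds than this note shows. Statements on the series, on what has been measured and on what is new or still open speak of the compounds shown alone.

Of the compounds shown here, two with a shared core have been measured in a functional assay on A549 cells (Homo sapiens) for inhibition, read by MTT assay, with a stated time of 48 h; a higher number here means a weaker inhibitor, a lower number a stronger inhibitor. Compound 1 `COc1ccc(/C=C\c2cc(OC)c(OC)c(OC)c2)cc1OC(=O)C1=CC(C)(C)N(O)C1(C)C` gives 160 nM, and compound 2 `COc1ccc(/C=C\c2cc(OC)c(OC)c(OC)c2)cc1OC(=O)C1=CC(C)(C)N(O)C(C)(C)C1` gives 150 nM. Among the compounds with values here, these are the only two numbers available and they lie within the scatter of each other, so compound 2 stands level with compound 1. Compound 3 `COc1ccc(/C=C\c2cc(OC)c(OC)c(OC)c2)cc1OC(=O)C1CC(C)(C)N(O)C(C)(C)C1` has not yet been measured. It differs from compound 2 on a carbonyl carbon: a group of 11 heavy atoms (9 carbon, 1 nitrogen, 1 oxygen; one six-membered non-aromatic ring with 1 hetero atom) in place of a group of 11 heavy atoms (9 carbon, 1 nitrogen, 1 oxygen; one six-membered non-aromatic ring with 1 hetero atom), on a carbonyl carbon. The group that leaves holds a double bond outside aromatic rings, whereas the 1-hydroxy-2,2,6,6-tetramethylpiperidin-4-yl group that enters holds none. Within the data shown here, only one measured step bears on this change: a 1.1-fold lower number from compound 1 to compound 2 (0.03 log units; within the scatter). There, a six-membered non-aromatic ring replaced a five-membered one on the carbonyl carbon. That step does not remove a double bond, so its guidance is indirect. No shift beyond the scatter is therefore expected in this assay. The expected size of the change is a 1.1-fold higher number from compound 2 to compound 3 (0.03 log units; within the scatter). Compound 3 is estimated at 160 nM, with an expected range from 70 nM to 380 nM.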

Compound 3, half-maximal inhibitory concentration: 170 nM
Beside the measured number, compound 3's estimate is 1.1-fold (0.03 log units) below it; the measured number falls inside the stated range.
By their numbers in this assay, from the lowest: compounds 2, 1 and 3 (each within the scatter of the next).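

Taking the double bond out of the ring on the carbonyl carbon, which leaves the 1-hydroxy-2,2,6,6-tetramethylpiperidin-4-yl group in its place, adds a change of a different kind at this position from the ring-size change seen earlier, and in this assay it gives a 1.1-fold higher number from compound 2 to compound 3 (0.05 log units; within the scatter). The five-membered ring group of compound 1 and the group of compound 3 also stand level, with a 1.1-fold higher number from compound 1 to compound 3 (0.03 log units; within the scatter), so across the three groups shown on this carbonyl carbon, neither ring size nor the double bond moves the number beyond the scatter. Nothing accompanying these numbers speaks to what lies behind this flat result.

Going by these compounds, all three compounds carry a hydroxyl on the ring nitrogen, so it remains open whether a plain hydrogen at that nitrogen would keep the number level. On these data alone, it also remains open whether a group of a different kind on this carbonyl carbon, such as an open-chain amine, a carboxylic acid or a longer alkyl chain, would stay within the scatter of these three compounds.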